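Swapping Methyl for Chloro on the Aryl Ring

The source may report more compounds than this note shows. Statements on the series, on what has been measured and on what is new or still open speak of the compounds shown alone.

Compound 1 `CNC(=O)c1cc(-c2ccnc(N)n2)[nH]c1-c1cc(Cl)ccc1C` gives 980 nM
Compound 2 `COc1ccc(Cl)cc1-c1[nH]c(-c2ccnc(N)n2)cc1C(N)=O` gives "not determined" (no result reported)
Compound 3 `Cc1ccc(C(F)(F)F)cc1-c1[nH]c(-c2ccnc(N)n2)cc1C(N)=O` gives 440 nM

In a functional assay on A2780 cells (Homo sapiens) for antiproliferative activity, with a stated time of 72 h (on this read-out lower numbers stand for stronger inhibition and higher numbers for weaker inhibition), only two of these compounds have a number, and compound 2 has no result. Compound 3 stands lowest at 440 nM and compound 1 lies higher at 980 nM with a gap beyond the usual scatter. These two differ in more than one place, so their gap cannot be pinned on any single group.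

Compound 4 `NC(=O)c1cc(-c2ccnc(N)n2)[nH]c1-c1cc(C(F)(F)F)ccc1Cl` departs from compound 3 by one swap, (chloro in place of methyl on an aromatic carbon), which puts chloro in place of methyl on an aromatic carbon, ortho to a large group and para to a trifluoromethyl group. Among the compounds with values here, no measured pair shows this swap, so the expectation rests on compound 3 alone, at 440 nM in this assay. The estimated move is a 1.1-fold higher number from compound 3 to compound 4 (0.06 log units; within the scatter) and this stays within the scatter, so no clear change is expected. For compound 4 the estimated value is 500 nM with an expected range from 170 nM to 1500 nM for repeat measurements.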

Compound 4, half-maximal inhibitory concentration: 1470 nM
Estimate against measurement, compound 4: 2.9-fold (0.47 log units) below; the measured number falls inside the stated range.
By their numbers in this assay, from the lowest: compound 3; then compounds 1 and 4 (each within the scatter of the next).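

This pair is the first among these compounds to differ in one place only, so a change in this assay can now be tied to a single swap: chloro in place of methyl on an aromatic carbon, ortho to a large group and para to a trifluoromethyl group, gives a 3.3-fold higher number from compound 3 to compound 4 (0.52 log units; beyond the scatter) on this read-out. The methyl here therefore cannot be exchanged for chloro without weaker inhibition, even though one heavy atom replaces one and the count of hydrogen-bond donors and acceptors stays at zero. Nothing in the data explains why the number rises.

As far as these compounds go, it remains open whether another group on this aromatic carbon, such as an amine or a nitrile, would hold compound 3 near 440 nM or move it further. Also open, from the compounds shown here alone, is whether the same swap would have a similar effect with a group such as a nitrile in place of the trifluoromethyl group.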